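The source may hold more compounds than are shown below. What is called first, only, known or untested is meant among the compounds shown, and "the series" means these compounds.

Three compounds share one core and differ only in the group carried on the five-membered ring. In an assay (Rattus norvegicus) for inhibition of Fatty-acid amide hydrolase 1 (Homo sapiens) (a lower number here means a stronger inhibitor, a higher number a weaker inhibitor), compound 1 `NS(=O)(=O)c1ccccc1-c1cnc(C(=O)CCCCCCc2ccccc2)o1` gives 1500 nM. Compound 2 `Cc1cccnc1-c1cnc(C(=O)CCCCCCc2ccccc2)o1` gives 15 nM in this assay, the lowest of the three numbers. Compound 3 `COc1ncc(-c2cnc(C(=O)CCCCCCc3ccccc3)o2)c(OC)n1` gives 26 nM in this assay, a number within the scatter of compound 2, while compound 1 lies far beyond it. Compound 4 `O=C(CCCCCCc1ccccc1)c1ncc(C(=O)N2CCOCC2)o1` has not yet been measured and differs from compound 2 in one place: (morpholin-4-yl)carbonyl in place of 3-methylpyridin-2-yl on an aromatic carbon. Among the compounds with values here, no measured pair shows this kind of change, so the direction rests on the spread already seen, and a rise beyond the scatter is expected in this assay, since compound 1 gives 1500 nM after a change at the same place. The expected step is a 17-fold higher number from compound 2 to compound 4 (1.22 log units; beyond the scatter). Compound 4 is estimated at 250 nM, within a range from 40 nM to 1500 nM.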

Compound 4, inhibition constant: 24 nM
Beside the measured number, compound 4's estimate is 10-fold (1.02 log units) above it; the whole stated range lies above it.
By their numbers in this assay, from the lowest: compounds 2, 4 and 3 (each within the scatter of the next); then compound 1.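

In this assay the swap of 3-methylpyridin-2-yl for (morpholin-4-yl)carbonyl gives a 1.6-fold higher number from compound 2 to compound 4 (0.20 log units; within the scatter) and so leaves the number within the scatter. This position therefore tolerates a non-aromatic ring attached through a carbonyl, not only the aromatic rings of compound 2 and compound 3. Compound 1 shows that a change at this place can still cost much, but leaving 3-methylpyridin-2-yl does not by itself do so.

Nothing given here accounts for this result. As far as these compounds go, whether a carboxylic acid or a piperidin-1-ylcarbonyl group at this place would behave the same remains open.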